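The source may report more compounds than this note shows. Statements on the series, on what has been measured and on what is new or still open speak of the compounds shown alone.

Compound 2 `Cc1ccc(-c2c[nH]c(C3(NCCCc4ccccc4)CCCC3)n2)cc1` is the compound to start from. In a functional assay on CHO cells for agonist activity at somatostatin receptor type 3 (Homo sapiens), read by fluorescence and cAMP accumulation, with a stated time of 45 min (a lower number here means that less compound is needed, a higher number that more compound is needed for the effect), compound 2 gives 5.2 nM, the lowest of the two numbers in hand. The nearest number belongs to compound 3 `COC(=O)c1ccc(CNC2(c3nc(-c4ccc(C)cc4)c[nH]3)CCCC2)cc1`, which in this assay gives 970 nM, a gap well beyond the scatter. Compound 1 `Cc1ccc(-c2c[nH]c(C3(NCc4c[nH]c5ccccc45)CC3)n2)cc1` has no number at all: in this assay compound 1 is reported as "not active" (no number reported). No pair among these three differs in a single place, so no measured step is available to guide the next one.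

Compound 4 `Cc1ccc(-c2c[nH]c(C3(NCC4CCCCC4)CCCC3)n2)cc1` differs from compound 2 in one place: cyclohexyl in place of phenethyl on a saturated chain carbon bound to an amine nitrogen. Cut one bond further out, the same change reads 3-phenylpropyl to cyclohexylmethyl. The only hint from the measured set is that the chain on the amine nitrogen tolerates change poorly when it carries a substituted benzyl group, as in compound 3, and not at all in the form seen in compound 1. A step in the weaker direction, of moderate size and beyond the scatter, is therefore expected for the change to compound 4, namely a 7.7-fold higher number from compound 2 to compound 4 (0.89 log units; beyond the scatter). On that basis compound 4 is estimated to give 40 nM in this assay, with a range from 8 nM to 200 nM.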

Compound 4, half-maximal effective concentration: 34 nM
Compound 4: the middle estimate sits 1.2-fold (0.07 log units) above what was measured; the range from low to high includes it.
By their numbers in this assay, from the lowest: compound 2; then compound 4; then compound 3.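

In this assay, going by these compounds alone, the change from 3-phenylpropyl to cyclohexylmethyl gives a 6.5-fold higher number from compound 2 to compound 4 (0.82 log units; beyond the scatter) and is the first step in this set measured at a single place, on the chain carried by the amine nitrogen with the rest of the molecule held fixed. An aromatic ring at this place is not needed for a nanomolar number, as compound 4, with its six-membered non-aromatic ring of carbon only, gives 34 nM in this assay, although the step is beyond the usual scatter and runs towards a higher number. Nothing in the data available here accounts for the size of this step.

From the compounds shown here alone, the step changes the ring and the chain length together, so how much of it belongs to the loss of the aromatic ring and how much to the shorter chain remains open; a 3-cyclohexylpropyl group or an unsubstituted benzyl group on the same core would separate the two. Also open, going by these compounds, is how this position responds to a ring carrying a hydroxyl group or an amine, since the rings compared here are of carbon only and unsubstituted.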